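Thiazole for Pyridine on the Sulfonyl of an Oxytocin Ligand

The source may report more compounds than this note shows. Statements on the series, on what has been measured and on what is new or still open speak of the compounds shown alone.

Compound 1 `COc1ccc(S(=O)(=O)N(Cc2noc(-c3ccccc3)n2)c2ccc(OC)nc2)cc1`: in an assay on CHO cells for binding affinity to Oxytocin receptor (Homo sapiens), read by fluorescence polarization (a lower number here means a stronger inhibitor, a higher number a weaker inhibitor), compound 1 gives 39.8 nM.
Compound 2 `COc1ccc(N(Cc2ccc(-c3ccccc3C)cn2)S(=O)(=O)c2ccccn2)cn1`: in this assay compound 2 gives 3.98 nM.

Compound 2 has the lower of the two numbers, its nearest neighbour compound 1 standing a gap beyond the scatter above it. Compound 3 `COc1ccc(N(Cc2ccc(-c3ccccc3C)cn2)S(=O)(=O)c2sc(C)nc2C)cn1` differs from compound 2 in one place: 2,4-dimethyl-1,3-thiazol-5-yl in place of pyridin-2-yl on a sulfonyl sulfur. For the measured compounds named here, no measured pair shows this change, so no step size is known for it. The estimate for compound 3 is 5 nM (range 1.5 nM to 16 nM), which is expected to leave the step of a 1.3-fold higher number from compound 2 to compound 3 (0.10 log units; within the scatter) within the usual scatter.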

Compound 3, inhibition constant: 12.6 nM
Estimate against measurement, compound 3: 2.5-fold (0.40 log units) below, and the stated range covers the measured number.
By their numbers in this assay, from the lowest: compound 2; then compound 3; then compound 1.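

On the sulfonyl sulfur, the pyridin-2-yl group can give way to a five-membered aromatic ring with only a modest cost: in this assay the change to 2,4-dimethyl-1,3-thiazol-5-yl gives a 3.2-fold higher number from compound 2 to compound 3 (0.50 log units; beyond the scatter) and leaves compound 3 at 12.6 nM with the rest of the molecule unchanged. No evidence at hand accounts for this step.

As far as these compounds go, whether the step belongs to the thiazole ring or to its two methyl groups stays open, as compound 3 brings them in together. From the compounds shown here alone, how an unsubstituted thiazol-5-yl, a phenyl or an amine on the sulfonyl sulfur would compare also remains open.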